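This account rests on a few compounds, and the source may have more. Where it says the series, first, only, none or still open, it means among the compounds named here.

Compound 1, with structure `CCN(CC)c1cc2[nH]c(C3CCCCC3)nc2cc1NC(=O)c1ccc(N(C)C)cc1`, carries a cyclohexyl on the shared core and a 4-(dimethylamino)phenyl amide on the other side. In an ADME assay on Vero cells (Chlorocebus sabaeus) for cytotoxicity, read by resazurin assay, with a stated time of 3 days (on this read-out lower numbers stand for stronger inhibition and higher numbers for weaker inhibition), compound 1 gives "not determined" (no result reported), so no single number stands for it, and what is known of its surroundings comes from two companions measured in the same way. Compound 2, with structure `CCOCCOC(=O)Nc1cc2nc(C3CCCCC3)[nH]c2cc1N(C)C`, reaches only a limit of the assay in this assay at > 100 ug/mL. Compound 3, with structure `CCCNC(=O)Nc1cc2nc(C3CCCCC3)[nH]c2cc1N1CCCC1`, likewise reaches only a limit in this assay at > 100 ug/mL. Both therefore sit at the limit of > 100 ug/mL in this assay, at which 2 of the 3 values shown sit, and neither gives a number that could be set against compound 1.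

For the measured compounds named here, the move to compound 4, with structure `CCN(CC)c1cc2[nH]c(C3CCCCC3)nc2cc1NC(=O)c1ccc(F)cc1`, is the single change (fluoro in place of dimethylamino on an aromatic carbon), which is fluoro in place of dimethylamino on an aromatic carbon. No measured pair shows the effect of such a change here, and with compound 1 itself without a number, no direction can be taken from the shown values. Given that compound 2 and compound 3 both sit at the limit, compound 4 is expected to behave in the same way, with an estimated value of 100 ug/mL, in the range 30 ug/mL to 200 ug/mL, most probably reported as a limit rather than a number.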

Compound 4, half-maximal inhibitory concentration: > 100 ug/mL
Compound 4: no number, only a limit (the forecaster's own chance of this, stated with the estimate: 70%); the middle value lies on the limit itself.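

In this assay, for the compounds shown here, compound 4 gives > 100 ug/mL, which is a limit of the assay and not a number; with no number for compound 1 either, no step from compound 1 to compound 4 can be read. The compounds shown leave open whether going from 4-(dimethylamino)phenyl to 4-fluorophenyl changes the read-out at all.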